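The source may report more compounds than this note shows. Statements on the series, on what has been measured and on what is new or still open speak of the compounds shown alone.

In an ADME assay on CEM-SS cells (Homo sapiens) for cytotoxicity, read by XTT assay, with a stated time of 6 days (a lower number here means that less compound is tolerated, a higher number that more compound is tolerated), compound 1 `CCCC(=O)OCSc1ccccc1C(=O)NCCC(N)=O`, which has no phenyl, gives > 100 uM, a limit of the assay and not a number. Within the data shown here, compound 2 `CCCC(=O)OCSc1ccccc1C(=O)NCC(=O)NCc1ccccc1` gives 29.3 uM, the only true number so far, so it cannot yet be ranked against another measured value. Compound 3 `CCCC(=O)OCSc1ccccc1C(=O)NCC(=O)NCCN(C)C` changes one part of compound 2: (dimethylamino)methyl in place of phenyl on a saturated chain carbon bound to an amide-type nitrogen. Put simply, (dimethylamino)methyl stands in place of phenyl on a saturated chain carbon bound to an amide-type nitrogen. Among the measured compounds shown here, no measured pair shows this change directly, so the guide is thin. With compound 1, also free of a phenyl, reported at > 100 uM, a modest move towards more compound being tolerated is expected. The expected change is a 2.0-fold higher number from compound 2 to compound 3 (0.31 log units; beyond the scatter), and it may prove hard to tell from the usual scatter. For compound 3 the estimated value is 60 uM, with an expected range of 20 uM to 100 uM.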

Compound 3, half-maximal toxic concentration: 76.9 uM
Compound 3: the middle estimate sits 1.3-fold (0.11 log units) below what was measured, and the stated range covers the measured number.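

In this assay, this position now has a step between two true numbers: (dimethylamino)methyl in place of phenyl on a saturated chain carbon bound to an amide-type nitrogen gives a 2.6-fold higher number from compound 2 to compound 3 (0.42 log units; beyond the scatter). Against the other compound without a phenyl, the reading is much weaker, with an at least 1.3-fold lower number from compound 1 to compound 3 (0.11 log units; that floor lies within the scatter), so compound 3 cannot be clearly set apart from compound 1. That comparison has no fixed size because compound 1 is reported only as a limit of the assay: the limit of > 100 uM in this assay, at which 1 of the 3 values shown sits.

This single step cannot separate the loss of the phenyl ring from the arrival of the dimethylamino group. A plain propyl chain or a carboxylic acid at this position would help to pull those two parts of the change apart.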